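The compounds below may be only part of what the source reports. "The series", "measured", "known", "first", "only" and "open" are said of these compounds alone.

Measured compounds:
- compound 1 `Cc1nn(C)c(Oc2cccc(F)c2)c1/C=N\CCCCCOc1cc2oc(=O)cc(C)c2cc1Cl`: 11800 nM
- compound 2 `Cc1nn(C)c(Oc2ccc(Cl)cc2)c1/C=N\CCCCCOc1cc2oc(=O)cc(C)c2cc1Cl`: 17500 nM
- compound 3 `Cc1nn(C)c(Oc2ccc(Br)cc2)c1/C=N\CCCCCOc1cc2oc(=O)cc(C)c2cc1Cl`: "not determined" (no result reported)

In a functional assay on SMMC-7721 cells (Homo sapiens) for antiproliferative activity, read by MTT assay, with a stated time of 72 h (on this read-out higher numbers stand for weaker inhibition and lower numbers for stronger inhibition), compound 1 gives 11800 nM. In this assay compound 2 gives 17500 nM. For the measured compounds named here, the step of a 1.5-fold higher number from compound 1 to compound 2 (0.17 log units; within the scatter) is the only measured step, and it lies within the scatter. For compound 3 there is no number in this assay; the result is given as "not determined" (no result reported), so compound 3 has no place on the numbers shown and the step to compound 4 has no measured starting point.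

Compound 4 `Cc1ccc(Oc2c(/C=N\CCCCCOc3cc4oc(=O)cc(C)c4cc3Cl)c(C)nn2C)cc1` differs from compound 3 by methyl in place of bromo on an aromatic carbon. Going by the values given here, no measured step bears directly on this change. Among the compounds with values here, the one measured step, from a 3-fluorophenyl to a 4-chlorophenyl, stayed within the scatter, and compounds 1 and 2 both sit in the same broad region of this assay. On that basis the expectation for compound 4 is a number in that same region, with no step beyond the scatter expected in either direction. The estimate for compound 4 in this assay is 15000 nM, expected to fall between 5000 nM and 45000 nM.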

Compound 4, half-maximal inhibitory concentration: 11100 nM
Estimate against measurement, compound 4: 1.4-fold (0.13 log units) above, within the range that was stated.
By their numbers in this assay, from the lowest: compounds 4, 1 and 2 (each within the scatter of the next).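

The step from compound 3 to compound 4 cannot be read, so the bromo to methyl change itself stays without a size in this assay. Methyl on this aromatic carbon, para to a large group, can still be set against the other two aryl ethers: it gives a 1.6-fold lower number from compound 2 to compound 4 (0.20 log units; within the scatter) against the 4-chlorophenyl and a 1.1-fold lower number from compound 1 to compound 4 (0.03 log units; within the scatter) against the 3-fluorophenyl. A carbon substituent at this place therefore stays level with both halogen-bearing compounds, and no evidence at hand accounts for this.

From the compounds shown here alone, whether an amine or a carboxylic acid at this place would give a step beyond the scatter remains open. So does whether the level response among compounds 1, 2 and 4 would hold with a longer chain in the linker.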